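From piperidin-1-yl to azepan-1-yl on the shared core

The compounds below may be only part of what the source reports. "The series", "measured", "known", "first", "only" and "open" are said of these compounds alone.

Three close relatives have been tested in an ADME assay on MT4 cells (Homo sapiens) for cytotoxicity, read by MTT assay, with a stated time of 4 days; on this read-out higher numbers stand for lower toxicity in this test and lower numbers for higher toxicity in this test. Compound 1 `CC(C)N(C)c1nc(Cc2c(F)cccc2F)cc(=O)[nH]1` gives 85000 nM, and compound 2 `CCCN(C)c1nc(Cc2c(F)cccc2F)cc(=O)[nH]1` gives 85000 nM. Compound 3 `O=c1cc(Cc2c(F)cccc2F)nc(N2CCCCC2)[nH]1` gives > 82000 nM, which is a limit of the assay and not a number. Its exact place on the scale is therefore unknown, and the steps to it from the other two cannot be sized: a step that the limit leaves unreadable from compound 1 to compound 3 and a step that the limit leaves unreadable from compound 2 to compound 3.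

Compound 4 `O=c1cc(Cc2c(F)cccc2F)nc(N2CCCCCC2)[nH]1` has azepan-1-yl in place of piperidin-1-yl on an aromatic carbon, between two ring nitrogen atoms: azepan-1-yl in place of piperidin-1-yl on an aromatic carbon. Within the data shown here, this makes the seven-membered ring the only structural difference from compound 3.

The one readable step among these compounds also changes the amine group, and it is no change at the digits printed from compound 1 to compound 2 (within the scatter). That single step is thin evidence, but it gives no reason to expect a large move. In this assay, no step beyond the usual scatter is therefore expected, and the estimated step is an at least 1.0-fold lower number from compound 3 to compound 4 (0.02 log units; that floor lies within the scatter). The assay may again report only a limit. For compound 4 the expected value is 78000 nM, with an estimated range from 40000 nM to 115000 nM.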

Compound 4, half-maximal cytotoxic concentration: > 78000 nM
Compound 4 ended at the assay's limit; the forecaster's own chance of this, stated with the estimate: 50%; the middle value sits exactly at the limit.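

Compound 4 also gives a limit of the assay and not a number, so its steps from compound 1, compound 2 and compound 3 cannot be read: the limit of > 78000 nM in this assay, at which 1 of the 4 values shown sits.

The compounds shown leave open where compound 3 and compound 4 truly stand in this assay, and whether azepan-1-yl in place of piperidin-1-yl changes the read-out at all.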